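Adding Chloro to Compound 3: An Expected Step

The compounds below may be only part of what the source reports. "The series", "measured", "known", "first", "only" and "open" are said of these compounds alone.

Four compounds share one core, and three of them have been measured in a functional assay on P388 cells (Mus musculus) for antiproliferative activity, read by colorimetric assay and MTT assay; on this read-out lower numbers stand for stronger inhibition and higher numbers for weaker inhibition. Compound 1 `COc1ccc(S(=O)(=O)Nc2cccc3cc[nH]c23)cc1` gives 1.1 ug/mL. Compound 2 `COc1ccc(S(=O)(=O)Nc2ccc(Cl)c3cc[nH]c23)cc1` gives 1.1 ug/mL. Compound 3 `O=[N+]([O-])c1ccc(S(=O)(=O)Nc2cccc3cc[nH]c23)cc1` gives 8.2 ug/mL, the highest of the three numbers. The step from compound 1 to compound 3 is a 7.5-fold higher number from compound 1 to compound 3 (0.87 log units; beyond the scatter), and the structural difference behind it is nitro in place of methoxy on an aromatic carbon.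

The change of interest is chloro in place of hydrogen on an aromatic carbon. It gives no change at the digits printed from compound 1 to compound 2 (within the scatter). Compound 4 `O=[N+]([O-])c1ccc(S(=O)(=O)Nc2cc(Cl)cc3cc[nH]c23)cc1` has not been measured; it differs from compound 3 by chloro in place of hydrogen on an aromatic carbon. Going by the values given here, this is the same kind of change as the one from compound 1 to compound 2, but not the same one: in compound 2 the chloro sits ortho to a fused ring and para to a large group, while in compound 4 it sits meta to a large group and para to a fused ring. The two cores differ by nitro in place of methoxy on an aromatic carbon.

Among the compounds with values here, with only one earlier example, and that at a different place, the expectation rests on compound 1 to compound 2, where chloro made no change within the scatter. The step from compound 3 to compound 4 is therefore expected to be about a 1.0-fold lower number from compound 3 to compound 4 (0.01 log units; within the scatter). Compound 4 is expected to give 8 ug/mL, plausibly between 3 ug/mL and 20 ug/mL.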

Compound 4, half-maximal inhibitory concentration: 13 ug/mL
Estimate against measurement, compound 4: 1.6-fold (0.21 log units) below, and the stated range covers the measured number.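

In this assay, swapping hydrogen for chloro gave a step that stays within the usual scatter on both the methoxy core and the nitro core, and the two steps cannot be told apart: the same change on two cores in this assay, no change at the digits printed (within the scatter) from compound 1 to compound 2 and a 1.6-fold higher number (0.20 log units; within the scatter) from compound 3 to compound 4, 1.6-fold (0.20 log units) apart, within the scatter of two such steps. The new result reads a 1.6-fold higher number from compound 3 to compound 4 (0.20 log units; within the scatter), so on this evidence compound 3 and compound 4 cannot be separated, just as compound 1 and compound 2 cannot, and the chloro change carried over from one core to the other without a measurable shift. This does not show that the change is neutral in general, since it rests on just two pairs of compounds, and the chloro sits at a different place on the ring in compound 2 than in compound 4, so the comparison changes both the core and the position at once and cannot separate the two.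

The compounds shown leave open how chloro would read at the place it holds in compound 4 if the core carried methoxy, and how it would read on the nitro core at the place it holds in compound 2. They also leave open whether a larger group at these places, such as bromo, an amine or a carboxylic acid, would stay within the scatter as chloro does.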